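A few compounds are considered here, and "the series" means these few. Any claim that something is new, unique, unknown or untested is made for them only; others in the source may bear on it.

In an assay on CHO cells for agonist activity at Neuronal acetylcholine receptor; alpha3/alpha6/beta2/beta3 (Homo sapiens), read by FLIPR and calcium flux (on this read-out higher numbers stand for larger maximal responses and lower numbers for smaller maximal responses), compound 1 `CCCC(=O)N1CC2CC(C1)N2` gives 92%. Compound 2 `O=C([C@H]1C[C@@H]1F)N1CC2CC(C1)N2` gives 85%, which stands lowest of the two numbers, nearest compound 1, and the step of a number 7 percentage points lower from compound 1 to compound 2 (within the scatter) lies within the scatter. Compound 3 `C[C@@H]1C[C@@H]1C(=O)N1CC2CC(C1)N2` differs from compound 2 by a group of 4 heavy atoms (4 carbon; one three-membered non-aromatic ring of carbon only) in place of a group of 4 heavy atoms (3 carbon, 1 fluorine; one three-membered non-aromatic ring of carbon only), on a carbonyl carbon. Within the data shown here, the one step that bears on this, an exchange of the group on the carbonyl carbon, was a number 7 percentage points lower from compound 1 to compound 2 (within the scatter), so in this assay no step beyond the scatter is expected here. Compound 3 is expected to give 88% in this assay, within 70% to 100%. The expected step of a number 3 percentage points higher from compound 2 to compound 3 (within the scatter) thus stays within the scatter.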

Compound 3, largest response reached (Emax), in percent of the reference or control that the assay uses: 87%
Compound 3: the middle estimate sits 1 percentage points above what was measured, and the stated range covers the measured number.
By their numbers in this assay, from the lowest: compounds 2, 3 and 1 (each within the scatter of the next).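

At this carbonyl carbon, the fluorine turns out not to matter for the response in this assay: replacing 2-fluorocyclopropyl with the all-carbon group that keeps the three-membered ring gives a number 2 percentage points higher from compound 2 to compound 3 (within the scatter). Set against the open propyl chain, that all-carbon ring group gives a number 5 percentage points lower from compound 1 to compound 3 (within the scatter), so a ring without fluorine also stays within the scatter. No evidence is available to explain these results. Still open, as far as these compounds go, is whether a larger group here, such as a phenyl ring, or a chain carrying an amine, would move the response beyond the scatter.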